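The source may hold more compounds than are shown below. What is called first, only, known or untested is meant among the compounds shown, and "the series" means these compounds.

Of the compounds shown here, three built on a shared core have been tested in a functional assay on liver (Rattus norvegicus, strain Sprague-Dawley) for inhibition, with a stated time of 1 h; a lower number here means a stronger inhibitor, a higher number a weaker inhibitor: compound 1 `C=CCCOc1cc(O)c2c(=O)c(OCCC=C)c(-c3ccc4c(c3)OC(c3ccc(OCCC=C)c(OC)c3)C(CO)O4)oc2c1`, compound 2 `COc1cc(C2Oc3cc(-c4oc5cc(OCC=C(C)C)cc(O)c5c(=O)c4O)ccc3OC2CO)ccc1OCC=C(C)C` and compound 3 `CCOC(=O)COc1cc(O)c2c(=O)c(O)c(-c3ccc4c(c3)OC(c3ccc(OCC(=O)OCC)c(OC)c3)C(CO)O4)oc2c1`. Compound 1 gives 67500 nM. Compound 3 gives 36400 nM, which cannot be told apart from the number for compound 1 given the usual scatter of repeated measurements. Compound 2 gives 28100 nM, and this gap to compound 1 is beyond the scatter, so compound 1 is the weaker inhibitor of that pair.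

The next compound is compound 4 `C=CCCOc1cc(O)c2c(=O)c(O)c(-c3ccc4c(c3)OC(c3ccc(OCCC=C)c(OC)c3)C(CO)O4)oc2c1`, and it differs from compound 1 in one place: hydrogen in place of but-3-en-1-yl on an oxygen on an aromatic ring. Hydrogen stands in place of but-3-en-1-yl on an oxygen on an aromatic ring, which turns (but-3-en-1-yl)oxy into hydroxy.

Within the data shown here, no tested pair differs in one place only, so the size of this step has not been seen directly. The best guide is that compound 2 at 28100 nM and compound 3 at 36400 nM already carry this hydroxy, although their other chains differ from those of compound 4. In this assay, a small move towards a lower number is therefore expected, near the edge of the scatter. The estimated step of a 1.9-fold lower number from compound 1 to compound 4 (0.27 log units; within the scatter) is modest. For compound 4 the estimated value is 36000 nM, with an expected range of 16000 nM to 75000 nM.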

Compound 4, half-maximal inhibitory concentration: 36200 nM
Beside the measured number, compound 4's estimate is 1.0-fold (0.00 log units) below it; measured number inside the range.
By their numbers in this assay, from the lowest: compounds 2, 4, 3 and 1 (each within the scatter of the next, the first and the last beyond it).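

Among these compounds, this is the first pair in the set that differs in one place only, so the swap of (but-3-en-1-yl)oxy for hydroxy can now be read directly: in this assay it gives a 1.9-fold lower number from compound 1 to compound 4 (0.27 log units; within the scatter). At this oxygen on an aromatic ring, then, compound 1 with its four-carbon chain and compound 4 with only a hydrogen cannot be told apart, so this one chain, double bond included, has no effect on the number that can be separated from ordinary repeat-to-repeat variation. No separate measurement is available to explain why the step is this small.

Still open, as far as these compounds go, is whether a different group on this same oxygen, such as a chain ending in a carboxylic acid or an amine, would shift the number beyond the scatter. Also open, from the compounds shown here alone, is whether replacing the but-3-en-1-yl chains that compound 4 still carries with hydrogen would give a similarly small step or a larger one.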